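A few compounds are considered here, and "the series" means these few. Any claim that something is new, unique, unknown or untested is made for them only; others in the source may bear on it.

Measured compounds in a functional assay on U2OS cells for antagonist activity at proto-oncogene Wnt-3 (Homo sapiens), read by a luciferase reporter, with a stated time of 18 h; a higher number here means that more compound is needed for the effect, a lower number that less compound is needed:
- compound 1, `CN(C)CC(=O)N1CCC(NS(=O)(=O)c2cc(S(=O)(=O)c3ccccc3)ccc2C(F)(F)F)CC1`, gives 280 nM
- compound 2, `O=C(CN1CCNCC1)N1CCC(NS(=O)(=O)c2cc(S(=O)(=O)c3ccccc3)ccc2C(F)(F)F)CC1`, gives 250 nM
- compound 3, `O=C(Cn1ccnc1)N1CCC(NS(=O)(=O)c2cc(S(=O)(=O)c3ccccc3)ccc2C(F)(F)F)CC1`, gives 230 nM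

Compound 1 carries the highest of the three numbers, but its nearest neighbour is compound 2, with a 1.1-fold lower number from compound 1 to compound 2 (0.05 log units; within the scatter), and its furthest is compound 3, with a 1.2-fold lower number from compound 1 to compound 3 (0.09 log units; within the scatter); every step among the three lies within the scatter, so no order among them can be read from this assay.

Compound 4, `CN(C)CC(=O)N1CCC[C@H]1C(=O)N1CCC(NS(=O)(=O)c2cc(S(=O)(=O)c3ccccc3)ccc2C(F)(F)F)CC1`, is not yet measured. It differs from compound 1 in one place: 1-(((dimethylamino)methyl)carbonyl)pyrrolidin-2-yl in place of (dimethylamino)methyl on a carbonyl carbon. The measured steps all alter the group on the saturated chain carbon bound to the carbonyl carbon and leave the number essentially unchanged; none inserts a ring between that chain and the core. They therefore bear only loosely on the present change. Given that tolerance, no step beyond the scatter is expected, with a wide range to allow for the untested insertion. For compound 4 the expected result is 350 nM, between 120 nM and 1000 nM, which means an expected 1.3-fold higher number from compound 1 to compound 4 (0.10 log units; within the scatter).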

Compound 4, half-maximal effective concentration: 310 nM
Compound 4: middle estimate off by 1.1-fold (0.05 log units), on the high side, within the range that was stated.
By their numbers in this assay, from the lowest: compounds 3, 2, 1 and 4 (each within the scatter of the next).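

In this assay the carbonyl carbon bound to the amide-type nitrogen in a ring accepts 1-(((dimethylamino)methyl)carbonyl)pyrrolidin-2-yl in place of (dimethylamino)methyl, with a 1.1-fold higher number from compound 1 to compound 4 (0.04 log units; within the scatter). The other two comparisons read the same way, with a 1.3-fold higher number from compound 3 to compound 4 (0.13 log units; within the scatter) and a 1.2-fold higher number from compound 2 to compound 4 (0.09 log units; within the scatter), so the tolerance seen earlier for changes on the saturated chain carbon also covers a change that adds a five-membered non-aromatic ring and a defined stereocentre. Nothing given here accounts for this tolerance.

From the compounds shown here alone, whether the opposite configuration at the stereocentre would also stay within the scatter remains open. So does the outcome for a carboxylic acid or a longer chain in place of the dimethylamino group, and for a six-membered ring in place of the pyrrolidine.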